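The source may hold more compounds than are shown below. What is called first, only, known or untested is meant among the compounds shown, and "the series" means these compounds.

Compound 1 `O=C(c1cccs1)n1nc(-c2cccnc2)c2ccccc2c1=O`: 12300 nM
Compound 2 `O=c1c2ccccc2c(-c2cccnc2)nn1CCSc1ccccc1`: 9120 nM

Both values come from a functional assay (trachea) with Cavia porcellus as the target; a higher number here means a weaker inhibitor, a lower number a stronger inhibitor. There, compound 2 gives 9120 nM, which lies within the usual scatter of the value for compound 1, so the two cannot be ranked. Compound 3 `O=C(O)CCCn1nc(-c2cccnc2)c2ccccc2c1=O`, not yet measured, keeps the shared core and differs from compound 2 by one change: carboxymethyl in place of phenylsulfanyl on a saturated chain carbon, two bonds along the chain from an aromatic nitrogen. Carboxymethyl thus stands in place of phenylsulfanyl on a saturated chain carbon, two bonds along the chain from an aromatic nitrogen. For the measured compounds named here, no measured step shows what such an exchange does. Going by the values given here, the only guide is that compound 1, at 12300 nM, and compound 2, at 9120 nM, carry different groups on the core yet sit within the scatter of each other. In this assay, a small move towards a higher number is therefore expected, possibly none beyond the scatter. The estimated change is a 1.6-fold higher number from compound 2 to compound 3 (0.22 log units; within the scatter). For compound 3, the expected value is 15000 nM, with an estimated range from 4000 nM to 55000 nM.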

Compound 3, half-maximal inhibitory concentration: > 100000 nM
Compound 3 gave a limit, no number (the forecaster's own chance of this, stated with the estimate: 20%); middle value at least 6.6-fold (0.82 log units) from the limit.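

In this assay, compound 3 gives > 100000 nM, which is a limit of the assay and not a number. Compound 1 and compound 2 could not be ranked, so they gave no sign that the group here mattered, yet the new steps show that it can: carboxymethyl in place of phenylsulfanyl gives an at least 10-fold higher number from compound 2 to compound 3 (1.04 log units; beyond the scatter), and 3-carboxypropyl in place of (thiophen-2-yl)carbonyl on an aromatic nitrogen gives an at least 8.1-fold higher number from compound 1 to compound 3 (0.91 log units; beyond the scatter). The true size of both steps remains unknown, and they are bounds only: the limit of > 100000 nM in this assay, at which 1 of the 3 values shown sits.

The compounds shown leave open whether the carboxylic acid itself or the loss of the aromatic ring of phenylsulfanyl accounts for the large step. A methyl ester or a primary amide on the same chain, or a carboxylic acid on a shorter chain, would bear on this.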